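Replacing a ring amide with a piperidinylmethyl amine

This account rests on a few compounds, and the source may have more. Where it says the series, first, only, none or still open, it means among the compounds named here.

Within the data shown here, compound 1 `O=C(C1CCCNC1)N1CCC2(CCN(c3nccc(NCc4ccc(Cl)cc4Cl)n3)CC2)C1` stands highest of the two solubility numbers measured so far: in a physicochemical assay for solubility, read by chemiluminescence, measured as kinetic solubility (a lower number here means a less soluble compound, a higher number a more soluble compound), compound 1 gives 186 ug/mL. Its nearest neighbour is compound 2 `Clc1ccc(CNc2ccnc(N3CCC4(CCN(C[C@@H]5CCCN5)C4)CC3)n2)c(Cl)c1`, which in this assay gives 56 ug/mL; the step of a 3.3-fold lower number from compound 1 to compound 2 (0.52 log units; beyond the scatter) goes with (pyrrolidin-2-yl)methyl in place of (piperidin-3-yl)carbonyl on an amine nitrogen in a ring. Compound 3 `Clc1ccc(CNc2ccnc(N3CCC4(CCN(CC5CCCCN5)C4)CC3)n2)c(Cl)c1` has not yet been measured. It differs from compound 1 in one place: (piperidin-2-yl)methyl in place of (piperidin-3-yl)carbonyl on an amine nitrogen in a ring. This is closely related to the change from compound 1 to compound 2: in both cases the (piperidin-3-yl)carbonyl leaves the same amine nitrogen, and a saturated ring carried on a methyl group enters in its stead, (piperidin-2-yl)methyl here where (pyrrolidin-2-yl)methyl entered in compound 2. Among the measured compounds shown here, the one measured step, a 3.3-fold lower number from compound 1 to compound 2 (0.52 log units; beyond the scatter), therefore bears directly on the case, and a decrease of broadly similar size is expected for compound 3, a 4.1-fold lower number from compound 1 to compound 3 (0.62 log units; beyond the scatter). Compound 3 is accordingly estimated at 45 ug/mL, with a likely range from 18 ug/mL to 110 ug/mL.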

Compound 3, solubility: 182 ug/mL
Estimate against measurement, compound 3: 4.0-fold (0.61 log units) below, outside the stated range (above it).
By their numbers in this assay, from the lowest: compound 2; then compounds 3 and 1 (each within the scatter of the next).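

In this assay the step of a 1.0-fold lower number from compound 1 to compound 3 (0.01 log units; within the scatter) shows that the (piperidin-3-yl)carbonyl on this amine nitrogen can give way to a (piperidin-2-yl)methyl with no change beyond the scatter, so leaving the carbonyl out does not in itself go with a lower number. The ring carried on the methyl group is what separates the two amines: the step of a 3.3-fold higher number from compound 2 to compound 3 (0.51 log units; beyond the scatter) goes with piperidin-2-yl in place of pyrrolidin-2-yl, which means that the drop seen earlier for compound 2 is not shared by every saturated ring on a methyl group at this position. Nothing in the data shown gives a reason for this difference between the two rings.

Compound 2 is drawn as a single mirror form and compound 3 is not, and the compounds shown do not separate that difference from the size of the ring. Also open, as far as these compounds go, is whether the same contrast would appear with an azetidin-2-yl on the methyl group, with a longer chain between the ring and the amine nitrogen, or with a (pyrrolidin-2-yl)carbonyl that keeps the carbonyl.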